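The compounds below may be only part of what the source reports. "The series", "measured", "known", "first", "only" and "open" are said of these compounds alone.

Compound 1 `CCNCC(=O)Nc1cc(OC)ccc1C(=O)c1ccc2c(c1)C=CC(C)(C)O2` carries an ethylamino group on a saturated chain carbon bound to a carbonyl carbon and gives 3990 nM in a functional assay on HCT-8 cells (Homo sapiens) for antiproliferative activity, read by MTT assay, with a stated time of 48 h; on this read-out lower numbers stand for stronger inhibition and higher numbers for weaker inhibition. Compound 2 `COc1ccc(C(=O)c2ccc3c(c2)C=CC(C)(C)O3)c(NC(=O)CN(C)C)c1` differs from compound 1 by dimethylamino in place of ethylamino on a saturated chain carbon bound to a carbonyl carbon; in this assay compound 2 gives 2420 nM, which is a step of a 1.6-fold lower number from compound 1 to compound 2 (0.22 log units; within the scatter). The core of compound 3 `CCNCC(=O)Nc1cc(OC)ccc1C(=O)c1cc(OC)c(OC)c(OC)c1` differs from that of compound 1; the difference between the two cores is not broken down here. In this assay compound 3 gives 1560 nM. Compound 4 `COc1ccc(C(=O)c2cc(OC)c(OC)c(OC)c2)c(NC(=O)CN(C)C)c1` relates to compound 3 by dimethylamino in place of ethylamino on a saturated chain carbon bound to a carbonyl carbon, the same change as from compound 1 to compound 2, at the same place. For the measured compounds named here, because the one earlier instance of this change gave a 1.6-fold lower number from compound 1 to compound 2 (0.22 log units; within the scatter), the step expected in this assay is a 1.4-fold lower number from compound 3 to compound 4 (0.15 log units; within the scatter), resting on that single pair. Compound 4 is therefore estimated at 1100 nM, between 550 nM and 2400 nM.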

Compound 4, half-maximal inhibitory concentration: 790 nM
Estimate against measurement, compound 4: 1.4-fold (0.14 log units) above; low and high end bracket the measured number.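

On the core of compound 3, dimethylamino in place of ethylamino gives a 2.0-fold lower number from compound 3 to compound 4 (0.30 log units; within the scatter) in this assay. Set beside the earlier instance, the change carries over from one core to the other with a step of like size: the same change on two cores in this assay, a 1.6-fold lower number (0.22 log units; within the scatter) from compound 1 to compound 2 and a 2.0-fold lower number (0.30 log units; within the scatter) from compound 3 to compound 4, 1.2-fold (0.08 log units) apart, within the scatter of two such steps. This shows agreement on two cores only; each step lies within the scatter, so neither one establishes a real difference between ethylamino and dimethylamino, and nothing follows for other cores.

Open, as far as these compounds go, is how a diethylamino group, a primary amine or a longer chain carrying the amine would read in this assay. Also open, from the compounds shown here alone, is whether a carboxylic acid at that place would keep any of the activity seen on these two cores.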